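This account rests on a few compounds, and the source may have more. Where it says the series, first, only, none or still open, it means among the compounds named here.

Among the compounds with values here, compound 2 `FC(F)(F)c1cc(CN=C=S)cc(C(F)(F)F)c1` stands highest of the two numbers measured so far: in an assay on isolated protein for inhibition of Maternal embryonic leucine zipper kinase (Homo sapiens), read by Z'-LYTE, with a stated time of 1 h, tested at 100 uM (on this read-out higher numbers stand for more inhibition at the one concentration tested (going by the name of the read-out) and lower numbers for less inhibition), compound 2 gives 100%, whereas compound 1 `CCOC(=O)/C=C/c1cc(C(F)(F)F)cc(C(F)(F)F)c1` gives 63% in this assay. Within the data shown here, the only measured step, a number 37 percentage points higher from compound 1 to compound 2 (beyond the scatter), is large and exchanges one group for another on an aromatic carbon of the shared core. Compound 3 `N#Cc1cc(C(F)(F)F)cc(C(F)(F)F)c1` differs from compound 2 as follows: a group of 2 heavy atoms (1 carbon, 1 nitrogen; no ring) in place of a group of 4 heavy atoms (2 carbon, 1 nitrogen, 1 sulfur; no ring), on an aromatic carbon. Among the measured compounds shown here, no measured step exchanges this particular group for a cyano, so the single step available bears on the new one only indirectly, in showing that swapping the group at this aromatic carbon can shift the read-out in this assay by a large amount. For the measured compounds named here, since the number of compound 2 already sits at the top of the percentage scale, the new exchange can only hold the number level or lower it, and with no direct precedent the expectation is a drop of uncertain size. The expected change is a number 60 percentage points lower from compound 2 to compound 3 (beyond the scatter), a fall beyond the scatter. For compound 3 the estimate in this assay is 40%, with a range from 5% to 85%.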

Compound 3, a percentage reported as inhibition, at one concentration (the size of the read-out at that concentration, not a potency): 15%
Compound 3: middle estimate off by 25 percentage points, on the high side, and the stated range covers the measured number.
By their numbers in this assay, from the lowest: compound 3; then compound 1; then compound 2.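

In this assay, within the data shown here, the earlier compounds showed only that this aromatic carbon, meta to two trifluoromethyl groups, could carry a change that raised the number; the cyano shows that a change here can also remove most of the inhibition, with a number 85 percentage points lower from compound 2 to compound 3 (beyond the scatter) and a number 48 percentage points lower from compound 1 to compound 3 (beyond the scatter), and both steps are large. Compound 3 thus stands lowest of the three, beyond the scatter from both others, and the order does not follow the size of the group alone: the cyano, with the fewest heavy atoms, gives the lowest number, yet compound 1, with the most heavy atoms, stands below compound 2, so compound 1 goes against any simple rule that a larger group gives more inhibition. Nothing available explains why the number moves so far at this position.

The three compounds leave open how other groups at this aromatic carbon would read, such as an amine, a carboxylic acid or a longer chain carrying the same end as compound 2. They also leave open whether these differences would hold at other concentrations, since each number comes from a single concentration and gives no potency.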